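A few compounds are considered here, and "the series" means these few. Any claim that something is new, unique, unknown or untested is made for them only; others in the source may bear on it.

Working notes on the series. The compounds share the core of compound 1, `CCCSc1nc(Cl)c2c(n1)N(Cc1ccccc1)C(C(=O)N1CCN(Cc3ccccc3)CC1)N2`, and differ in the amide attached to the saturated ring carbon. In a functional assay on MGC-803 cells (Homo sapiens) for antiproliferative activity, read by MTT assay, with a stated time of 72 h (a lower number here means a stronger inhibitor, a higher number a weaker inhibitor), compound 1 gives 51200 nM. Among the measured compounds shown here, compound 2, `CCCSc1nc(Cl)c2c(n1)N(Cc1ccccc1)C(C(=O)N1CCN(C(=O)OC(C)(C)C)CC1)N2`, gives 32000 nM in this assay, and the step of a 1.6-fold lower number from compound 1 to compound 2 (0.20 log units; within the scatter) is the only single-place step among the measured compounds. Compound 3, `CCCSc1nc(Cl)c2c(n1)N(Cc1ccccc1)C(C(=O)NCCNC(=O)OC(C)(C)C)N2`, carries the open-chain amide. In this assay compound 3 gives only a limit, > 64000 nM. This is the limit (the limit of > 64000 nM in this assay, at which 1 of the 3 values shown sits). Compound 3 therefore stands on the numbers shown as a limit alone, and no step from compound 1 or compound 2 to it can be sized. Compound 4, `CCCSc1nc(Cl)c2c(n1)N(Cc1ccccc1)C(C(=O)N1CCN(C)CC1)N2`, differs from compound 3 by 4-methylpiperazin-1-yl in place of (2-((tert-butoxycarbonyl)amino)ethyl)amino on a carbonyl carbon. For the measured compounds named here, no measured step covers this exchange directly; the step of a 1.6-fold lower number from compound 1 to compound 2 (0.20 log units; within the scatter) bears on it only in showing that changing the group on the ring nitrogen of the amide moves this assay within the scatter. Since compound 4 returns to the ring amide of compound 1 and compound 2, the value of compound 4 is expected in their neighbourhood, estimated at 45000 nM with a range of 15000 nM to 120000 nM. The expected step from compound 3 to compound 4, an at least 1.4-fold lower number from compound 3 to compound 4 (0.15 log units; that floor lies within the scatter), starts from a limit and is therefore not sized as a measured step would be.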

Compound 4, half-maximal inhibitory concentration: > 64000 nM
Compound 4: a limit, no number; the forecaster's own chance of this, stated with the estimate: 30%; middle value at least 1.4-fold (0.15 log units) from the limit.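

The value of compound 4 in this assay is a limit and not a number, so a ring amide at this carbonyl carbon does not by itself give a readable value, and the step from compound 3 cannot be read, since two limits face each other: the limit of > 64000 nM in this assay, at which 2 of the 4 values shown sit.

Methyl in place of tert-butoxycarbonyl on the ring nitrogen gives an at least 2.0-fold higher number from compound 2 to compound 4 (0.30 log units; that floor lies within the scatter), a floor only, so the true size of this change remains unknown. Replacing benzyl on the same nitrogen with methyl, which the structures record as hydrogen in place of phenyl on a saturated chain carbon bound to an amine nitrogen in a ring, gives an at least 1.2-fold higher number from compound 1 to compound 4 (0.09 log units; that floor lies within the scatter), and this too is a floor that shows no change beyond the scatter.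

Still open, from the compounds shown here alone, is whether a free amine on the ring nitrogen, an acetyl group there or a longer chain such as phenethyl would give a value that reads as a number. Also open, going by these compounds, is whether a free primary amine at the end of the open chain, in place of the tert-butoxycarbonyl-protected one, would do so.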